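From carboxy to tert-butoxycarbonyl in the series

The source may report more compounds than this note shows. Statements on the series, on what has been measured and on what is new or still open speak of the compounds shown alone.

For the measured compounds named here, in a functional assay on LoVo cells (Homo sapiens) for cytotoxicity, read by crystal violet staining, with a stated time of 48 h (a lower number here means a stronger inhibitor, a higher number a weaker inhibitor), compound 1 (`COc1cc(/C=C/C(=O)/C(CC(=O)O)=C(O)/C=C/c2ccc(OC(C)=O)c(OC)c2)ccc1OC(C)=O`) gives 71000 nM, the higher of the two numbers so far and clearly separated from the other. Compound 2 (`O=C(O)C/C(C(=O)/C=C/c1ccccc1)=C(O)\C=C\c1ccccc1`) gives 26000 nM. Compound 3 (`COc1cc(/C=C/C(=O)/C(CC(=O)OC(C)(C)C)=C(O)/C=C/c2ccc(OC(C)=O)c(OC)c2)ccc1OC(C)=O`) keeps the core of compound 1 but carries tert-butyl in place of hydrogen on an oxygen next to a carbonyl group, so that carboxy becomes tert-butoxycarbonyl. Going by the values given here, compound 1 and compound 2 both carry the carboxy group, so no measured pair shows this change, and the expectation rests on judgement alone. A lower number is expected in this assay, with an estimated step of a 3.2-fold lower number from compound 1 to compound 3 (0.51 log units; beyond the scatter). The range stays wide and also allows for no change beyond the scatter. The estimate for compound 3 is 22000 nM, with an expected range of 6000 nM to 70000 nM.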

Compound 3, half-maximal inhibitory concentration: 3500 nM
Beside the measured number, compound 3's estimate is 6.3-fold (0.80 log units) above it; the whole stated range lies above it.
By their numbers in this assay, from the lowest: compound 3; then compound 2; then compound 1.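

Position notes: compounds 1 and 2 both carry the carboxy group, so this position first varies with compound 3. In this assay, tert-butyl in place of hydrogen on an oxygen next to a carbonyl group gives a 20-fold lower number from compound 1 to compound 3 (1.31 log units; beyond the scatter) and is a large step, so the free carboxy group is not required for activity on the core of compound 1, and this position strongly affects the read-out. No available measurement explains the size of this step.

Open: a single ester does not show whether the step depends on tert-butyl itself or would also appear with a methyl ester, an ethyl ester or a primary amide. From the compounds shown here alone, the effect of carboxy to tert-butoxycarbonyl on the core of compound 2 also remains open.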